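A few compounds are considered here, and "the series" means these few. Any claim that something is new, unique, unknown or untested is made for them only; others in the source may bear on it.

Of the compounds shown here, three of this small set have been measured in a functional assay on the whole organism with Scenedesmus acutus as the target, with a stated time of 20 h; on this read-out lower numbers stand for stronger inhibition and higher numbers for weaker inhibition. Compound 1 `COC(=O)CSc1cc(/N=c2\sc(=S)n3n2CCCC3)c(F)cc1Cl` gives 389 nM in this assay, the highest number of the three and thus the weakest inhibition. Compound 2 `S=c1s/c(=N\c2ccc(OCc3ccc(Cl)cc3)cc2)n2n1CCCC2` gives 120 nM in this assay, and compound 3 `CC(C)Oc1cc(-n2c(=S)n3n(c2=S)CCCC3)c(F)cc1Cl` gives 67.6 nM, both beyond the scatter from compound 1.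

Compound 4 `Fc1cc(Cl)ccc1/N=c1\sc(=S)n2n1CCCC2` is not yet measured. It differs from compound 1 in one place: hydrogen in place of ((methoxycarbonyl)methyl)sulfanyl on an aromatic carbon. Within the data shown here, no measured pair here shows what removing such a group does, so the expectation rests only on the values already seen. Compound 4 is expected to stay close to compound 1, with any step from compound 1 to compound 4 of about a 1.3-fold higher number from compound 1 to compound 4 (0.11 log units; within the scatter), not clearly beyond the scatter. The estimate for compound 4 is 500 nM, within 150 nM to 1800 nM.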

Compound 4, half-maximal inhibitory concentration: 91.2 nM
Beside the measured number, compound 4's estimate is 5.5-fold (0.74 log units) above it; the whole stated range lies above it.
By their numbers in this assay, from the lowest: compounds 3, 4 and 2 (each within the scatter of the next); then compound 1.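

In this assay, hydrogen in place of ((methoxycarbonyl)methyl)sulfanyl on this aromatic carbon gives a 4.3-fold lower number from compound 1 to compound 4 (0.63 log units; beyond the scatter), a modest gain in inhibition. So the large group is not required for inhibition on the shared core, and its loss does not cost strength in this assay. Nothing in the data explains why the number falls.

Still open, from the compounds shown here alone, is how a small group on this carbon, such as methoxy or an amine, would compare with hydrogen. Also open, going by these compounds, is whether a free carboxylic acid in place of the methyl ester would change the number of compound 1.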